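A Smaller Fused Ring at the Same Aromatic Carbon

The compounds below may be only part of what the source reports. "The series", "measured", "known", "first", "only" and "open" are said of these compounds alone.

Three compounds share one core and were measured in a functional assay on HCT-116 cells (Homo sapiens) for inhibition, read by MTT assay, with a stated time of 72 h, tested at 20 uM; on this read-out higher numbers stand for more inhibition at the one concentration tested (going by the name of the read-out) and lower numbers for less inhibition:
compound 1 `CN(c1ccc(Oc2ncnc3sccc23)cc1)c1nccc(N2CCCC2)n1` gives 42.2%;
compound 2 `CN(c1ccc(Oc2ncnc3sccc23)cc1)c1nccc(N2CCCCC2)n1` gives 52.2%;
compound 3 `CN(c1ccc(Oc2ncnc3sccc23)cc1)c1nccc(N2CCc3ccccc3C2)n1` gives 57.7%.

Compound 3 holds the highest of the three numbers. One step is a number 5.5 percentage points higher from compound 2 to compound 3 (within the scatter), which is within the scatter, so those two cannot be ranked; another step is a number 15.5 percentage points higher from compound 1 to compound 3 (beyond the scatter), which is beyond the scatter. Between compound 1 and compound 2 the step is a number 10 percentage points higher from compound 1 to compound 2 (within the scatter), again within the scatter.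

Compound 4 `CN(c1ccc(Oc2ncnc3sccc23)cc1)c1nccc(N2CCc3ccccc32)n1` differs from compound 3 in one place: 2,3-dihydro-1H-indol-1-yl in place of 1,2,3,4-tetrahydroisoquinolin-2-yl on an aromatic carbon. The fused group keeps its six-membered aromatic ring of carbon only, while its non-aromatic ring with 1 hetero atom goes from six-membered to five-membered. The closest measured parallel is the step between compound 1 and compound 2, where a five-membered ring became a six-membered one and the number rose by an amount within the scatter; the step from compound 1 to compound 3 was larger. Reading that comparison backwards, a modest fall in this assay is expected, probably within the scatter. Compound 4 is therefore expected to give about 46%, between 34% and 58%. That would be an expected step of a number 11.7 percentage points lower from compound 3 to compound 4 (beyond the scatter), not a measured one.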

Compound 4, a percentage reported as inhibition, at one concentration (the size of the read-out at that concentration, not a potency): 20%
The estimate for compound 4 lay 26 percentage points above the measured number; measured number outside the range, below it.
By their numbers in this assay, from the lowest: compound 4; then compounds 1, 2 and 3 (each within the scatter of the next, the first and the last beyond it).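

In this assay, the change at this aromatic carbon, next to the ring nitrogen, brings by far the largest shift yet seen among these compounds (a number 37.7 percentage points lower from compound 3 to compound 4 (beyond the scatter)), although both groups keep the same six-membered aromatic ring of carbon only and differ in whether their non-aromatic ring is six-membered or five-membered. The 2,3-dihydro-1H-indol-1-yl group also falls short of the two unfused rings (a number 32.2 percentage points lower from compound 2 to compound 4 (beyond the scatter); a number 22.2 percentage points lower from compound 1 to compound 4 (beyond the scatter)), which makes compound 4 the lowest of the four and shows that the fused aromatic ring does not by itself go with a higher number, since compound 3 carries that ring too and holds the highest number. Nothing available here accounts for this fall.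

The compounds shown leave open how a morpholin-4-yl group, an isoindolin-2-yl group or an open-chain dimethylamino group would read at this carbon. They also leave open how these compounds would rank by potency, since each number gives the size of the inhibition at a single concentration in a single cell line.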